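Swapping phenyl for pyridin-2-yl on a triazepinone core

The source may hold more compounds than are shown below. What is called first, only, known or untested is meant among the compounds shown, and "the series" means these compounds.

Compound 1 `CC(C)(C)C(=O)CN1C(=O)N(CC(=O)Nc2cccc(-n3ccnc3)c2)N=C(C2CCCCC2)c2ccccc21` in a functional assay on stomach for binding affinity to Gastrin/cholecystokinin type B receptor (Rattus norvegicus) (on this read-out lower numbers stand for tighter binding and higher numbers for weaker binding), gives 871 nM.
Compound 2 `CNc1cccc(NC(=O)CN2N=C(c3ccccc3)c3ccccc3N(CC(=O)C(C)(C)C)C2=O)c1` in this assay gives 132 nM.
Compound 3 `CN(C)c1cccc(NC(=O)CN2N=C(C3CCCCC3)c3ccccc3N(CC(=O)C(C)(C)C)C2=O)c1` in this assay gives 91.2 nM.

Among these three numbers compound 2 stands second highest. Its nearest neighbour is compound 3, whose number lies within the scatter of that of compound 2; the furthest is compound 1, which lies beyond the scatter. Compound 4 `CNc1cccc(NC(=O)CN2N=C(c3ccccn3)c3ccccc3N(CC(=O)C(C)(C)C)C2=O)c1` has not yet been measured. It differs from compound 2 in one place: pyridin-2-yl in place of phenyl on a carbon with a double bond to nitrogen.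

Within the data shown here, only one measured step joins two compounds that differ in a single place, a 9.6-fold lower number from compound 1 to compound 3 (0.98 log units; beyond the scatter), and it concerns the aromatic carbon on the anilide side, not the carbon with a double bond to nitrogen where compound 4 is altered. Among the measured compounds shown here, no measured step therefore bears directly on the change from compound 2 to compound 4. Without such a precedent, the reasonable expectation for compound 4 in this assay is a step of a 1.0-fold lower number from compound 2 to compound 4 (0.01 log units; within the scatter), that is, none beyond the scatter. The estimate for compound 4 is 130 nM, expected to fall between 45 nM and 380 nM.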

Compound 4, dissociation constant: 224 nM
Compound 4: middle estimate off by 1.7-fold (0.24 log units), on the low side; the measured number falls inside the stated range.
By their numbers in this assay, from the lowest: compounds 3, 2 and 4 (each within the scatter of the next, the first and the last beyond it); then compound 1.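

In this assay, putting pyridin-2-yl in place of phenyl on the carbon with a double bond to nitrogen gives a 1.7-fold higher number from compound 2 to compound 4 (0.23 log units; within the scatter). Among these compounds, this is the first measured step at this position, since the earlier step concerned only the aromatic carbon on the anilide side, and it shows that a ring nitrogen and one hydrogen-bond acceptor can enter here without moving the number beyond the scatter. No measured evidence is available to account for this outcome.

The compounds shown leave open whether pyridin-3-yl, pyridin-4-yl or thiophen-2-yl would be tolerated equally on this carbon. As far as these compounds go, it also remains open whether the same swap would give a similar step with dimethylamino rather than methylamino on the anilide ring.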